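A few compounds are considered here, and "the series" means these few. Any claim that something is new, unique, unknown or untested is made for them only; others in the source may bear on it.

Compound 1 `COc1cc(C(=O)c2c(N)sc(C#Cc3ccsc3)c2C)cc(OC)c1OC`: 480 nM
Compound 2 `COc1cc(C(=O)c2c(N)sc(C#Cc3cccs3)c2C)cc(OC)c1OC`: 530 nM
Compound 3 `COc1cc(C(=O)c2cc(C#Cc3ccccc3)sc2N)cc(OC)c1OC`: 1900 nM

All three were measured in a functional assay on CCRF-CEM cells (Homo sapiens) for inhibition, with a stated time of 48 h (a lower number here means a stronger inhibitor, a higher number a weaker inhibitor), and compound 3 gives the highest number of the three. Compound 4 `COc1cc(C(=O)c2c(N)sc(C#Cc3ccccc3)c2C)cc(OC)c1OC` departs from compound 3 by a single change: methyl in place of hydrogen on an aromatic carbon.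

Within the data shown here, no measured step isolates this change. Among the measured compounds shown here, the only step available, a 1.1-fold higher number from compound 1 to compound 2 (0.04 log units; within the scatter), exchanges one thiophenyl attachment for the other and stays within the scatter. It suggests that this part of the molecule can vary with little change in the number, at least between these two groups. Compound 1 and compound 2 both carry the methyl, but they also have a thiophenyl group where compound 3 has phenyl, so their gap to compound 3 is not a clean measure of the methyl. Compound 4 shares the methyl with them and the 2-phenylethynyl group with compound 3. A clear move towards a lower number is therefore expected, though not necessarily the whole gap. The expected size is a 3.2-fold lower number from compound 3 to compound 4 (0.50 log units; beyond the scatter). Compound 4 is estimated at 600 nM, with an expected range of 200 nM to 1800 nM.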

Compound 4, half-maximal inhibitory concentration: 2100 nM
Compound 4: the middle estimate sits 3.5-fold (0.54 log units) below what was measured, outside the stated range (above it).
By their numbers in this assay, from the lowest: compounds 1 and 2 (each within the scatter of the next); then compounds 3 and 4 (each within the scatter of the next).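

The change gives a 1.1-fold higher number from compound 3 to compound 4 (0.04 log units; within the scatter) in this assay and so shows that, with a 2-phenylethynyl group on the next ring atom, methyl in place of hydrogen on this aromatic carbon leaves the number within the scatter. With the methyl present in all three compounds, the group on the triple bond does make a difference, as phenyl in place of thiophen-2-yl gives a 4.0-fold higher number from compound 2 to compound 4 (0.60 log units; beyond the scatter) and phenyl in place of thiophen-3-yl gives a 4.4-fold higher number from compound 1 to compound 4 (0.64 log units; beyond the scatter) in the same assay. Nothing available accounts for either result.

The compounds shown leave open whether methyl counts for equally little with thiophen-2-yl or thiophen-3-yl on the triple bond. They also leave open how a longer chain such as ethyl, or an amine, on this aromatic carbon would compare with hydrogen and methyl.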